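Trimming a Piperidine Ester Side Chain to a Formamide

The compounds below may be only part of what the source reports. "The series", "measured", "known", "first", "only" and "open" are said of these compounds alone.

compound 1 `CN(CCC#N)C[C@H]1CN(c2ccc(-n3cc(-c4ccccn4)cn3)c(F)c2)C(=O)O1`: 1.9
compound 2 `COC(=O)CC1CCN(C[C@H]2CN(c3ccc(-n4cc(-c5ccccn5)cn4)c(F)c3)C(=O)O2)CC1`: 1.78
compound 3 `CCC(=O)NC[C@H]1CN(c2ccc(-n3cc(-c4ccccn4)cn3)c(F)c2)C(=O)O1`: 2.2

All three share one core and differ only in the group on a saturated chain carbon bound to a saturated ring carbon. In a physicochemical assay for lipophilicity, read by HPLC, measured as octanol-water partition (a higher number here means a more lipophilic compound, a lower number a more polar compound), compound 2 gives 1.78, the lowest of the three numbers; its gap to compound 1 is within the scatter, while the step of a number 0.42 log units higher from compound 2 to compound 3 (beyond the scatter) lies beyond it. Compound 4 `O=CNC[C@H]1CN(c2ccc(-n3cc(-c4ccccn4)cn3)c(F)c2)C(=O)O1` is not yet measured; its change from compound 2 is formylamino in place of 4-((methoxycarbonyl)methyl)piperidin-1-yl on a saturated chain carbon bound to a saturated ring carbon. Among the measured compounds shown here, the only measured step that swaps the same leaving group for an amide is a number 0.42 log units higher from compound 2 to compound 3 (beyond the scatter), a modest rise; formylamino carries less carbon than propanoylamino, so a smaller rise or a drop is expected. Compound 4 is estimated at 1.4 (range 0.9 to 1.9), a step of a number 0.38 log units lower from compound 2 to compound 4 (beyond the scatter).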

Compound 4, partition coefficient: 1.19
Compound 4: middle estimate off by 0.21 log units, on the high side; low and high end bracket the measured number.
By their numbers in this assay, from the lowest: compound 4; then compounds 2, 1 and 3 (each within the scatter of the next, the first and the last beyond it).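

In this assay, hydrogen in place of ethyl on a carbonyl carbon gives a number 1.01 log units lower from compound 3 to compound 4 (beyond the scatter) and is the largest step yet at this position. Formylamino also gives a number 0.59 log units lower from compound 2 to compound 4 (beyond the scatter) and a number 0.71 log units lower from compound 1 to compound 4 (beyond the scatter) and so places compound 4 lowest of the four. An amide here does not fix the direction: propanoylamino gave a number 0.42 log units higher from compound 2 to compound 3 (beyond the scatter) in place of the same piperidine group, so what stands on the carbonyl carbon decides it among these compounds. As far as these compounds go, whether acetylamino would land partway along the step, or a plain amine would behave differently again, stays open. Nothing shown explains why the step is so large.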